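The compounds below may be only part of what the source reports. "The series", "measured", "known", "first", "only" and "open" are said of these compounds alone.

Notes on the cyclic peroxide acids

The series is measured in a functional assay on MDA-MB-435 cells (Homo sapiens) for inhibition; a lower number here means a stronger inhibitor of growth, a higher number a weaker inhibitor of growth. Compound 1 `C=C1CCCC(C)(C)C1CC[C@]1(C)CC[C@@H]([C@@H](C)C(=O)O)OO1` is one of two measured compounds. Compound 1 gives > 10000 nM in this assay, and this is a limit of the assay rather than a number; compound 1 therefore sits at the limit of > 10000 nM in this assay, at which 1 of the 2 values shown sits. The second measured compound is compound 2 `C=C1CCC[C@H]2[C@](C)(CC[C@]3(C)CC[C@@H]([C@@H](C)C(=O)O)OO3)[C@@H](C)CC[C@]12C`, which carries a larger carbocyclic portion on the shared core. In this assay compound 2 gives 2060 nM. Within the data shown here, no pair of measured compounds differs in a single place, so no measured step is available to anchor the change considered here.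

The step followed goes from compound 1 to compound 3 `C=C1CCCC(C)(C)C1CC[C@@]1(C)CC[C@H]([C@@H](C)C(=O)O)OO1`. The difference between them is the two compounds have the same atoms and bonds; at least one stereo element is drawn with a configuration in one of them and without one in the other: 2 of 4 stereo elements differ; a stereocentre at a saturated ring carbon is drawn R in compound 1 and S in compound 3; a stereocentre at a saturated ring carbon is drawn S in compound 1 and R in compound 3. Nothing in the measured data reports how inversion at these two ring stereocentres affects growth inhibition, so no size or direction of step can be drawn from the measured compounds; the expectation is a step near zero, within the scatter. Compound 3 is accordingly expected at 9000 nM, in the range 2500 nM to 30000 nM. This estimate means a step of an at least 1.1-fold lower number from compound 1 to compound 3 (0.04 log units; that floor lies within the scatter), and a reported limit rather than a number is expected as the more likely outcome.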

Compound 3, concentration for 50% growth inhibition: 2690 nM
For compound 3 the middle estimate is 3.3-fold (0.52 log units) above the measured one; measured number inside the range.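

Compound 1 gives > 10000 nM in this assay, which is a limit of the assay and not a number. Among these compounds, with atoms and bonds unchanged, inverting the two stereocentres at saturated ring carbons gives an at least 3.7-fold lower number from compound 1 to compound 3 (0.57 log units; beyond the scatter), the first readable step, and it shows that configuration at these two carbons alone can shift growth inhibition beyond the scatter. The step is only a floor, and its full size stays unknown because of this: the limit of > 10000 nM in this assay, at which 1 of the 3 values shown sits.

From the compounds shown here alone, the two stereocentres change together, so the share of each stays open, as does the weight that the drawn configurations can bear: the fact that one of compounds 1 and 3 is drawn with a defined configuration and the other without, at the place where they differ Also open is whether the same inversion would carry a similar step on the larger carbocyclic portion of compound 2, and whether it would persist with a methyl ester or an amide in place of the carboxylic acid.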